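The source may report more compounds than this note shows. Statements on the series, on what has been measured and on what is new or still open speak of the compounds shown alone.

Compound 1 `O=C(Nc1ccccc1-c1ccccc1)[C@@H]1CCCN1C(=O)CSc1nc2ccccc2[nH]1` gives 10 nM in an assay on CHO cells for displacement of a labelled ligand from Orexin/Hypocretin receptor type 1 (Homo sapiens) (on this read-out higher numbers stand for weaker inhibition and lower numbers for stronger inhibition), the second highest of the three numbers shown, standing between compound 2 `Cn1c(SCC(=O)N2CCC[C@H]2C(=O)Nc2ccccc2-c2ccccc2)nc2ccccc21` with 3 nM and compound 3 `O=C(Nc1ccccc1-c1ccccc1)[C@@H]1CCCN1C(=O)CCc1nc2ccccc2[nH]1` with 40 nM. The measured steps touch other parts of the shared core: a 3.3-fold lower number from compound 1 to compound 2 (0.52 log units; beyond the scatter) and a 4.0-fold higher number from compound 1 to compound 3 (0.60 log units; beyond the scatter), while a 13-fold higher number from compound 2 to compound 3 (1.12 log units; beyond the scatter) combines both changes. Compound 4 `O=C(Nc1ccccc1Oc1ccccc1)[C@@H]1CCCN1C(=O)CSc1nc2ccccc2[nH]1` differs from compound 1 in a further place: phenoxy in place of phenyl on an aromatic carbon. Within the data shown here, no measured step bears on this change, and nothing in the numbers points to a shift in either direction. The expected step is no change at the digits printed from compound 1 to compound 4 (within the scatter), no larger than the scatter. Compound 4 is therefore estimated to give about 10 nM in this assay, within a range of 3 nM to 40 nM.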

Compound 4, inhibition constant: 69 nM
Compound 4: middle estimate off by 6.9-fold (0.84 log units), on the low side, outside the stated range (above it).
By their numbers in this assay, from the lowest: compound 2; then compound 1; then compounds 3 and 4 (each within the scatter of the next).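

In this assay, among these compounds, phenoxy in place of phenyl on this aromatic carbon gives a 6.9-fold higher number from compound 1 to compound 4 (0.84 log units; beyond the scatter), so this place, ortho to a large group, responds to the change, which the earlier compounds, all carrying phenyl there, could not show. The step runs toward weaker inhibition, with one oxygen and one hydrogen-bond acceptor entering. No evidence here accounts for the shift.

On these data alone, whether a benzyl or anilino group would behave like phenoxy remains open. So does whether phenoxy would have a similar effect on the core of compound 2.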